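This account rests on a few compounds, and the source may have more. Where it says the series, first, only, none or still open, it means among the compounds named here.

Measured so far in a functional assay on CCRF-CEM cells (Homo sapiens) for antiproliferative activity, with a stated time of 72 h; on this read-out higher numbers stand for weaker inhibition and lower numbers for stronger inhibition:

Compound 1 `COc1ccc(-c2csc(=O)n2-c2cc(OC)c(OC)c(OC)c2)cc1` gives 1800 nM.
Compound 2 `COc1ccc(-c2c(Cl)sc(=O)n2-c2cc(OC)c(OC)c(OC)c2)cc1` gives > 20000 nM, which is a limit of the assay and not a number.
Compound 3 `COc1ccc(-n2c(-c3cc(OC)c(OC)c(OC)c3)csc2=O)cc1[N+](=O)[O-]` gives 2700 nM.

The move from compound 1 to compound 2 is chloro in place of hydrogen on an aromatic carbon. It gives an at least 11-fold higher number from compound 1 to compound 2 (1.04 log units; beyond the scatter). The value of compound 2 sits at the limit of > 20000 nM in this assay, at which 1 of the 3 values shown sits.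

Compound 3 and compound 1 lie within the usual scatter of each other; the difference between the two cores is not broken down here.

Compound 4 `COc1ccc(-n2c(-c3cc(OC)c(OC)c(OC)c3)c(Cl)sc2=O)cc1[N+](=O)[O-]` has not yet been measured. Relative to compound 3 it carries chloro in place of hydrogen on an aromatic carbon. Within the data shown here, this is the same kind of change as the one from compound 1 to compound 2, though not the same: there the chloro enters next to the ring atom that bears a 4-methoxyphenyl group (8 heavy atoms), whereas in compound 3 that ring atom bears a large group.

Compound 4 is expected at 30000 nM, with a range of 12000 nM to 80000 nM, because the matching step gave an at least 11-fold higher number from compound 1 to compound 2 (1.04 log units; beyond the scatter). The step this estimate implies is an 11-fold higher number from compound 3 to compound 4 (1.05 log units; beyond the scatter), and a limit rather than a number is the more likely outcome.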

Compound 4, half-maximal inhibitory concentration: > 20000 nM
Compound 4 ended at the assay's limit; the forecaster's own chance of this, stated with the estimate: 70%; the middle value lies beyond the limit too.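

In this assay chloro in place of hydrogen on the aromatic carbon next to the ring sulfur again weakens inhibition, giving an at least 7.4-fold higher number from compound 3 to compound 4 (0.86 log units; beyond the scatter). Compound 4 gives > 20000 nM, which is a limit of the assay and not a number. The direction of the change therefore carries from the core of compound 1 to the core of compound 3, with both steps beyond the scatter, but the data do not show how large the step is on either core or whether the two cores respond equally: the same change on two cores in this assay, an at least 11-fold higher number (1.04 log units; beyond the scatter) from compound 1 to compound 2 and an at least 7.4-fold higher number (0.86 log units; beyond the scatter) from compound 3 to compound 4; the limit leaves it open whether they differ.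

The compounds shown leave open whether this weakening is specific to chloro or would also follow from fluoro, methyl or a nitrile on the same ring carbon. Also open, as far as these compounds go, is whether the chloro step would keep its direction on a core carrying an amine in place of the nitro group of compound 3.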